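Shifting substituents on the pendant phenyl ring

A few compounds are considered here, and "the series" means these few. Any claim that something is new, unique, unknown or untested is made for them only; others in the source may bear on it.

Measured so far in an ADME assay on microsomes from liver (Rattus norvegicus) for metabolic stability, read by LC-MS, using NADPH, at 37 degrees C; on this read-out lower numbers stand for a shorter-lived compound and higher numbers for a longer-lived compound:
compound 1, `Cc1oc(-c2ccc(Cl)c(Cl)c2)nc1CN1CCC(C(=O)NCCCN2C[C@H](C)C[C@H](C)C2)CC1` — > 0.5 h
compound 2, `Cc1oc(-c2c(Br)cccc2Br)nc1CN1CCC(C(=O)NCCCN2C[C@H](C)C[C@H](C)C2)CC1` — 0.035 h
compound 3, `Cc1cccc(-c2nc(CN3CCC(C(=O)NCCCN4C[C@H](C)C[C@H](C)C4)CC3)c(C)o2)c1` — > 0.5 h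

Compound 3 sits at a limit of this assay, giving > 0.5 h, a limit rather than a number. Compound 1 likewise gives > 0.5 h, also a limit. Among the compounds with values here, compound 2 is the one compound with a read number, 0.035 h. Two of the three values therefore rest at the same edge of the assay, (the limit of > 0.5 h in this assay, at which 2 of the 3 values shown sit), and the step that the two limits leave unreadable from compound 1 to compound 3 cannot be read. The two steps that can be read both set compound 2 apart: an at least 14-fold lower number from compound 1 to compound 2 (1.15 log units; beyond the scatter) and an at least 14-fold higher number from compound 2 to compound 3 (1.15 log units; beyond the scatter).

Compound 4, `COc1cccc(OC)c1-c1nc(CN2CCC(C(=O)NCCCN3C[C@H](C)C[C@H](C)C3)CC2)c(C)o1`, differs from compound 3 by 2,6-dimethoxyphenyl in place of 3-methylphenyl on an aromatic carbon. Within the data shown here, the entering 2,6-dimethoxyphenyl shares its substitution pattern with the 2,6-dibromophenyl of compound 2, and the only change that brought this pattern onto the ring, an at least 14-fold lower number from compound 1 to compound 2 (1.15 log units; beyond the scatter), was large and downward; its reversal, an at least 14-fold higher number from compound 2 to compound 3 (1.15 log units; beyond the scatter), was large and upward. Going by these compounds, on that basis the step from compound 3 is expected to be downward, an at least 3.3-fold lower number from compound 3 to compound 4 (0.52 log units; beyond the scatter), though the dimethoxy group itself is untested here. Compound 4 is expected to give 0.15 h, between 0.03 h and 0.6 h.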

Compound 4, half-life: 0.2 h
Estimate against measurement, compound 4: 1.3-fold (0.12 log units) below; the measured number falls inside the stated range.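

Compound 4 gives a second read number in this assay for a phenyl ring with the substitution pattern of the 2,6-dibromophenyl of compound 2, and it shows that the groups in that pattern matter, with a 5.7-fold higher number from compound 2 to compound 4 (0.76 log units; beyond the scatter). Both steps from the other substitution patterns also run downward, an at least 2.5-fold lower number from compound 3 to compound 4 (0.39 log units; beyond the scatter) and an at least 2.5-fold lower number from compound 1 to compound 4 (0.39 log units; beyond the scatter), so across these four compounds the two 2,6-substituted rings give the lower numbers, and no compound shown goes against this. Going by these compounds, the full size of those two steps stays unknown and the step between compound 1 and compound 3 cannot be read, because both compounds rest at the same edge of the assay: the limit of > 0.5 h in this assay, at which 2 of the 4 values shown sit.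

On these data alone, it remains open whether the lower numbers follow the substitution pattern shared by 2,6-dibromophenyl and 2,6-dimethoxyphenyl itself or the bromine and methoxy groups as such, which would take those groups in another pattern on the ring to settle. As far as these compounds go, how an unsubstituted phenyl or a pyridine ring would stand at this position on the five-membered ring also remains open.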